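Replacing the succinimide in compound 1 with a thiazole

This account rests on a few compounds, and the source may have more. Where it says the series, first, only, none or still open, it means among the compounds named here.

Compound 1 `CCCCOC(=O)NS(=O)(=O)c1sc(CC(C)C)cc1-c1ccc(CN2C(=O)CCC2=O)cc1` is the weakest point of the set measured so far. In an assay on membranes from uterus for displacement of a labelled ligand from Angiotensin type II receptor (Sus scrofa), with a stated time of 1.5 h (a higher number here means a weaker inhibitor, a lower number a stronger inhibitor), compound 1 gives only a limit, > 10000 nM, and no number; this is the limit of > 10000 nM in this assay, at which 1 of the 3 values shown sits. Compound 2 `CCCCOC(=O)NS(=O)(=O)c1sc(CC(C)C)cc1-c1ccc(C(=O)c2cccs2)cc1` gives 18.8 nM in this assay, and compound 3 `CCCCOC(=O)NS(=O)(=O)c1sc(CC(C)C)cc1-c1ccc(CN2CCCC2=O)cc1` gives 3.5 nM. Both steps away from compound 1 are large: an at least 530-fold lower number from compound 1 to compound 2 (2.72 log units; beyond the scatter), and an at least 2800-fold lower number from compound 1 to compound 3 (3.45 log units; beyond the scatter). Between the two measured replacements the step is a 5.4-fold lower number from compound 2 to compound 3 (0.73 log units; beyond the scatter).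

Compound 4 `CCCCOC(=O)NS(=O)(=O)c1sc(CC(C)C)cc1-c1ccc(Cc2nccs2)cc1` has not been measured in this assay. It differs from compound 1 by 1,3-thiazol-2-yl in place of 2,5-dioxopyrrolidin-1-yl on a saturated chain carbon bound to an aromatic carbon. Both measured steps from compound 1 bear on this change, since each exchanges the 2,5-dioxopyrrolidin-1-yl-bearing group for another five-membered ring and each leaves the limit far behind. A step of similar size, downward from the limit, is therefore expected for compound 4, its expected size being an at least 500-fold lower number from compound 1 to compound 4 (2.69 log units; beyond the scatter). With a five-membered aromatic ring with 2 hetero atoms rather than a non-aromatic ring, a number between the values of compound 2 and compound 3 is the natural expectation, though a wider range is kept given that compound 1 contributes only a limit. For compound 4 the estimated value in this assay is 20 nM, expected to lie between 3 nM and 200 nM.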

Compound 4, inhibition constant: 3.2 nM
Compound 4: the middle estimate sits 6.3-fold (0.80 log units) above what was measured, and the stated range covers the measured number.
By their numbers in this assay, from the lowest: compounds 4 and 3 (each within the scatter of the next); then compound 2. At a limit, above all of these: compound 1.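

On the saturated chain carbon bound to an aromatic carbon, 1,3-thiazol-2-yl and 2-oxopyrrolidin-1-yl cannot be told apart in this assay, with a 1.1-fold lower number from compound 3 to compound 4 (0.04 log units; within the scatter), so a ring carbonyl is not needed here for a value at this level. The poor standing of compound 1 therefore goes with 2,5-dioxopyrrolidin-1-yl itself and not with every five-membered ring on this carbon, and an at least 3100-fold lower number from compound 1 to compound 4 (3.49 log units; beyond the scatter) starts from a limit of the assay: the limit of > 10000 nM in this assay, at which 1 of the 4 values shown sits. Against (thiophen-2-yl)carbonyl the change gives a 5.9-fold lower number from compound 2 to compound 4 (0.77 log units; beyond the scatter), which puts both rings carried on the saturated chain carbon on the same side of compound 2.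

Still open, on these data alone, is whether the ring nitrogen or the ring sulfur of 1,3-thiazol-2-yl matters at all, which a phenyl or a 2-pyridyl group on the same carbon would test. Also open is how far this position accepts a charged group such as an amine or a carboxylic acid, since every group shown here carries no net charge.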